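Compound 4: a heteroaryl exchange from compound 2

The source may hold more compounds than are shown below. What is called first, only, known or untested is meant among the compounds shown, and "the series" means these compounds.

Three compounds have numbers in an assay on cells for displacement of a labelled ligand from prostaglandin E2 receptor EP4 subtype (Homo sapiens), read by scintillation counting; a higher number here means a weaker inhibitor, a lower number a stronger inhibitor. Compound 1 `CC(=O)c1ccc(-c2ccc(OCc3cc(C(=O)O)oc3C)cc2)cc1` gives 150 nM, compound 2 `Cc1oc(C(=O)NS(=O)(=O)c2ccccc2)cc1COc1ccc(-c2ccccc2)cc1` gives 25 nM, and compound 3 `COc1ccc(-c2ccc(OCc3cc(C(=O)NS(=O)(=O)c4ccc(CN)cc4)oc3C)cc2)cc1` gives 100 nM. Among these three, compound 2 stands lowest: the nearest number, that of compound 3, and the furthest, that of compound 1, both lie beyond the usual scatter above it. Compound 4 `COc1ccc(-c2ccc(OCc3cc(C(=O)NS(=O)(=O)c4ccccc4)oc3C)cc2)nc1` has not yet been measured in this assay. It differs from compound 2 in one place: 5-methoxypyridin-2-yl in place of phenyl on an aromatic carbon. Among the measured compounds shown here, no step of this kind connects two measured compounds, so its size cannot be read from the data. Compound 3, which also bears a methoxy group but with a different sulfonyl part, gives 100 nM, which hints that such a change need not move the number far. The step from compound 2 to compound 4 is expected to be small, a 1.6-fold higher number from compound 2 to compound 4 (0.20 log units; within the scatter), leaning toward a slightly higher number and possibly within the scatter. Compound 4 is therefore estimated at 40 nM, in a range from 12 nM to 130 nM.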

Compound 4, inhibition constant: 22 nM
The estimate for compound 4 lay 1.8-fold (0.26 log units) above the measured number; low and high end bracket the measured number.
By their numbers in this assay, from the lowest: compounds 4 and 2 (each within the scatter of the next); then compounds 3 and 1 (each within the scatter of the next).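

In this assay, the exchange of phenyl for 5-methoxypyridin-2-yl, on an aromatic carbon para to a large group, gives a 1.1-fold lower number from compound 2 to compound 4 (0.06 log units; within the scatter), a step within the scatter. Among the compounds shown here, this is the first step read at this position, and it shows that the larger ring, with its ring nitrogen and methoxy group, can stand there without moving the number beyond the scatter. Nothing shown here accounts for this outcome.

The ring nitrogen and the methoxy group enter together, so the share of each remains unresolved, and plain pyridin-2-yl or a phenyl carrying methoxy on the same benzenesulfonyl scaffold would separate them. On these data alone, it also remains open whether a longer chain such as ethoxy, or an amine in place of the methoxy group, would be accepted at this position.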